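Changing the aryl group on a weak growth inhibitor

The source may hold more compounds than are shown below. What is called first, only, known or untested is meant among the compounds shown, and "the series" means these compounds.

In a functional assay on A549 cells (Homo sapiens) for inhibition, read by CCK-8 assay, with a stated time of 72 h, tested at 1 uM (on this read-out higher numbers stand for more inhibition of growth at the one concentration tested and lower numbers for less inhibition of growth), compound 1 `CN(C)C(=O)c1cc2cnc(Nc3ccc(NC(=O)C4(C(=O)Nc5ccc(Cl)cc5)CC4)cc3)nc2n1C1CCCC1` gives 24.7%, and compound 2 `Nc1ccc(NC(=O)C2(C(=O)Nc3ccc(F)cc3)CC2)cc1F`, a smaller molecule, gives 16.3%. Compound 3 `CN(C)C(=O)c1cc2cnc(Nc3ccc(NC(=O)C4(C(=O)Nc5ccc(Cl)c(C(F)(F)F)c5)CC4)cc3)nc2n1C1CCCC1` stands lowest of the three at 1.1%.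

Compound 4 `CN(C)C(=O)c1cc2cnc(Nc3ccc(NC(=O)C4(C(=O)Nc5ccc(O)cc5)CC4)cc3)nc2n1C1CCCC1` has 4-hydroxyphenyl in place of the 4-chloro-3-(trifluoromethyl)phenyl of compound 3 on an amide-type nitrogen: 4-hydroxyphenyl in place of 4-chloro-3-(trifluoromethyl)phenyl on an amide-type nitrogen. Within the data shown here, one measured step bears on this change: a number 23.6 percentage points lower from compound 1 to compound 3 (beyond the scatter), with trifluoromethyl in place of hydrogen on an aromatic carbon. Compound 4 carries no trifluoromethyl, so it resembles compound 1 at that spot, and much of that drop may be recovered. Among the measured compounds shown here, no measured step shows how a hydroxy-bearing ring compares with a chlorine-bearing one, so the uncertainty stays wide. A rise somewhat smaller than that drop is therefore expected, estimated as a number 16.9 percentage points higher from compound 3 to compound 4 (beyond the scatter). For compound 4 the estimated value is 18%, with an expected range from 4% to 38%.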

Compound 4, percent growth inhibition at one concentration: 93.6%
Compound 4: the middle estimate sits 75.6 percentage points below what was measured; the whole stated range lies below it.
By their numbers in this assay, from the lowest: compound 3; then compounds 2 and 1 (each within the scatter of the next); then compound 4.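

Among these compounds, the aryl group on this amide-type nitrogen proves to be far more decisive than the earlier compounds suggested: in this assay, replacing 4-chloro-3-(trifluoromethyl)phenyl with 4-hydroxyphenyl gives a number 92.5 percentage points higher from compound 3 to compound 4 (beyond the scatter). Among the compounds shown here, the cleaner comparison changes only one group, hydroxy in place of chloro on an aromatic carbon, and still gives a number 68.9 percentage points higher from compound 1 to compound 4 (beyond the scatter), so removing trifluoromethyl is not the whole story. No measurement shown here explains why this change has so large an effect.

Whether the gain is specific to hydroxy remains open, as the compounds shown do not reveal how a methoxy group, an amine or a carboxylic acid would read in its place. Testing at a single concentration also leaves open how compound 4 would respond across a range of concentrations.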